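Styryl variant at the saturated ring carbon of the shared core

The source may hold more compounds than are shown below. What is called first, only, known or untested is meant among the compounds shown, and "the series" means these compounds.

In a functional assay on Ehrlich cells (Mus musculus) for cytotoxicity, tested at 100 ug/mL (a higher number here means a stronger effect of the compound at the concentration tested, a lower number a weaker effect), compound 1 `COc1cc(N2C(N)=C(C#N)C(c3ccc(OC)c4ccccc34)C3=C2CC(C)(C)CC3=O)cc(OC)c1OC` gives 40%.
Compound 2 `COc1ccccc1C1C(C#N)=C(N)N(c2cc(OC)c(OC)c(OC)c2)C2=C1C(=O)CC(C)(C)C2` gives 100% in this assay.
Compound 3 `COc1cc(N2C(N)=C(C#N)C(c3ccccc3Cl)C3=C2CC(C)(C)CC3=O)cc(OC)c1OC` gives 20% in this assay.

Compound 3 stands lowest of the three numbers in this assay: the nearest is compound 1, the step being a number 20 percentage points lower from compound 1 to compound 3 (beyond the scatter); the furthest is compound 2, with a number 80 percentage points lower from compound 2 to compound 3 (beyond the scatter).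

Compound 4 `COc1cc(N2C(N)=C(C#N)C(/C=C/c3ccccc3)C3=C2CC(C)(C)CC3=O)cc(OC)c1OC` is not yet measured. Relative to compound 3 the change is 2-phenylethenyl in place of 2-chlorophenyl on a saturated ring carbon.

Among the compounds with values here, the steps that bear on this change are those which swap the group on the same saturated ring carbon: a number 60 percentage points higher from compound 1 to compound 2 (beyond the scatter) and a number 20 percentage points lower from compound 1 to compound 3 (beyond the scatter). Both are beyond the scatter, one large and one modest, and they go in opposite directions, so a swap at this carbon can move this assay strongly either way. Within the data shown here, no measured step introduces a 2-phenylethenyl group, so the direction for compound 4 rests on the spread of the three aryl variants rather than on a matching precedent. The expectation is a step of a number 25 percentage points higher from compound 3 to compound 4 (beyond the scatter), i.e. a move upward from the lowest value of the set but without reaching the level of compound 2.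

For compound 4 the estimated value in this assay is 45%, within a range of 15% to 90%.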

Compound 4, a percentage reported as activity, at one concentration (the size of the read-out at that concentration, not a potency): 40%
Estimate against measurement, compound 4: 5 percentage points above; the measured number falls inside the stated range.
By their numbers in this assay, from the lowest: compound 3; then compounds 1 and 4 (each within the scatter of the next); then compound 2.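

In this assay, the series now includes a group at this saturated ring carbon that carries a double bond outside aromatic rings, and 2-phenylethenyl gives a number 20 percentage points higher from compound 3 to compound 4 (beyond the scatter), a modest step up from 2-chlorophenyl. The same group gives no change at the digits printed from compound 1 to compound 4 (within the scatter), so it cannot be told apart from 4-methoxynaphthalen-1-yl in this read-out, while a number 60 percentage points lower from compound 2 to compound 4 (beyond the scatter) leaves the 2-methoxyphenyl of compound 2 alone at the top of the four compounds. Thus, among the compounds shown, the high read-out belongs only to 2-methoxyphenyl, and the data on hand offer no explanation for this.

From the compounds shown here alone, it remains open whether the double bond itself matters, which a saturated 2-phenylethyl chain at the same carbon would test, and whether a methoxy group on the phenyl ring of 2-phenylethenyl would bring the read-out closer to that of compound 2. Also open, going by these compounds, are the effects of an amine or a carboxylic acid on that ring, and, with a single tested concentration, how these compounds rank in potency.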